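A few compounds are considered here, and "the series" means these few. Any claim that something is new, unique, unknown or untested is made for them only; others in the source may bear on it.

Measured compounds:
compound 1 `O=C(CCC(=O)OCCCCCCSc1ccc([N+](=O)[O-])c2nonc12)Nc1ccccc1F` — 9890 nM
compound 2 `COc1ccc(NC(=O)CCC(=O)OCCCCCCSc2ccc([N+](=O)[O-])c3nonc23)cc1OC` — 6470 nM

In an assay on isolated protein for inhibition of glutathione S-transferase P (Homo sapiens), with a stated time of 10 min (on this read-out higher numbers stand for weaker inhibition and lower numbers for stronger inhibition), compound 2 gives 6470 nM. Within the data shown here, only one other compound has been measured, and the two stand close together: a 1.5-fold lower number from compound 1 to compound 2 (0.18 log units; within the scatter), a gap that the assay cannot tell apart from repeat noise. Compound 3 `CCN(CC)CCCNC(=O)CCC(=O)OCCCCCCSc1ccc([N+](=O)[O-])c2nonc12` has not yet been measured. It differs from compound 2 by 3-(diethylamino)propyl in place of 3,4-dimethoxyphenyl on an amide-type nitrogen. Among the measured compounds shown here, the single measured step, a 1.5-fold lower number from compound 1 to compound 2 (0.18 log units; within the scatter), exchanges one aromatic group for another on that same amide-type nitrogen and moves little; the step to compound 3 instead replaces the aromatic group with an open chain carrying a further nitrogen, and no measured pair shows what such a change does here. The expected step is therefore small, a 1.1-fold higher number from compound 2 to compound 3 (0.03 log units; within the scatter), with a wide band of uncertainty around it. Compound 3 is expected to give 7000 nM, somewhere between 2500 nM and 20000 nM.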

Compound 3, half-maximal inhibitory concentration: 9550 nM
Compound 3: middle estimate off by 1.4-fold (0.13 log units), on the low side; measured number inside the range.
By their numbers in this assay, from the lowest: compounds 2, 3 and 1 (each within the scatter of the next).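

In this assay, putting the open-chain 3-(diethylamino)propyl in place of the aromatic 3,4-dimethoxyphenyl on the amide-type nitrogen gives a 1.5-fold higher number from compound 2 to compound 3 (0.17 log units; within the scatter), and putting it in place of 2-fluorophenyl gives a 1.0-fold lower number from compound 1 to compound 3 (0.02 log units; within the scatter). Across these three compounds, then, losing the ring and adding a further nitrogen moves the number no more than repeat measurements would, something the earlier swap of one aromatic group for another could not show. No available measurement speaks to the reason for this result.

From the compounds shown here alone, whether a carboxylic acid, a primary amine or a plain hexyl chain on that nitrogen would also leave the number in place remains open. Also open, going by these compounds, is how much of the inhibition comes from the shared core rather than from this group.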